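This account rests on a few compounds, and the source may have more. Where it says the series, first, only, none or still open, it means among the compounds named here.

Compound 2 `CC(=O)c1cccc(C2=NC(c3ccc(F)cc3)(c3ccc(F)cc3)CN2)c1` shows the lowest number of the three measured compounds in an assay on LM cells for displacement of a labelled ligand from Neuropeptide Y receptor type 5 (Homo sapiens) (a higher number here means a weaker inhibitor, a lower number a stronger inhibitor), giving 44 nM. Compound 3 `OCc1cccc(C2=NC(c3ccc(F)cc3)(c3ccc(F)cc3)CN2)c1` gives 59 nM, the step of a 1.3-fold higher number from compound 2 to compound 3 (0.13 log units; within the scatter). Compound 1 `Fc1ccc(C2(c3ccc(F)cc3)CNC(c3ccc(C(F)(F)F)cc3)=N2)cc1` gives 160 nM, a higher number that lies beyond the scatter. Compound 4 `N#Cc1cccc(C2=NC(c3ccc(F)cc3)(c3ccc(F)cc3)CN2)n1` is unmeasured and differs from compound 2 in one place: 6-cyanopyridin-2-yl in place of 3-acetylphenyl on a carbon with a double bond to nitrogen. For the measured compounds named here, the only measured step on that same aromatic group, a 1.3-fold higher number from compound 2 to compound 3 (0.13 log units; within the scatter), was small; no measured pair exchanges a ring of carbon only for one with a ring nitrogen or brings in a nitrile, so the present change has no direct precedent. A modest rise is expected, a 1.6-fold higher number from compound 2 to compound 4 (0.20 log units; within the scatter), with wide uncertainty. Compound 4 is estimated at 70 nM, between 20 nM and 250 nM.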

Compound 4, half-maximal inhibitory concentration: 39 nM
Compound 4: the middle estimate sits 1.8-fold (0.25 log units) above what was measured, and the stated range covers the measured number.
By their numbers in this assay, from the lowest: compounds 4, 2 and 3 (each within the scatter of the next); then compound 1.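

At the carbon with a double bond to nitrogen, the whole aromatic group can be exchanged, not only its side group. With 6-cyanopyridin-2-yl in place of 3-acetylphenyl the step is small (a 1.1-fold lower number from compound 2 to compound 4 (0.05 log units; within the scatter)), and with it in place of 3-(hydroxymethyl)phenyl the step is also small (a 1.5-fold lower number from compound 3 to compound 4 (0.18 log units; within the scatter)), so a ring nitrogen and a nitrile together are tolerated here; no measurement shown gives a reason for this. From the compounds shown here alone, neither the ring nitrogen nor the nitrile appears alone, so their separate contributions stay open. Also open, going by these compounds, is how an amine or a carboxylic acid on this ring would behave.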